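The source may hold more compounds than are shown below. What is called first, only, known or untested is meant among the compounds shown, and "the series" means these compounds.

Values in a functional assay for inhibition, with Homo sapiens as the target; a higher number here means a weaker inhibitor, a lower number a stronger inhibitor:
- Compound 1 `CCCC(Oc1ccc2c(c1)c(SC(C)(C)C)c(CC(C)(C)C(=O)O)n2Cc1ccc(Cl)cc1)c1ccc2ccccc2n1`: > 52 nM, a limit of the assay and not a number
- Compound 2 `CC(C)(C)Sc1c(CC(C)(C)C(=O)O)n(Cc2ccc(Cl)cc2)c2ccc(OCc3cc4ccccc4cn3)cc12`: 3 nM
- Compound 3 `CC(C)(C)Sc1c(CC(C)(C)C(=O)O)n(Cc2ccc(Cl)cc2)c2ccc(OCc3nc4cc(C(F)(F)F)ccc4s3)cc12`: 22 nM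

Of the two true numbers, compound 2 at 3 nM has the lower, and its gap to compound 3 at 22 nM lies beyond the scatter. Compound 4 `Cc1nc2ccc(COc3ccc4c(c3)c(SC(C)(C)C)c(CC(C)(C)C(=O)O)n4Cc3ccc(Cl)cc3)cc2s1`, not yet measured, carries 2-methyl-1,3-benzothiazol-6-yl in place of isoquinolin-3-yl on a saturated chain carbon bound to an oxygen on an aromatic ring. Within the data shown here, no measured step isolates this change. Since compound 2 at 3 nM is the best number available, a moderate loss beyond the scatter is expected. The estimated change is a 5.0-fold higher number from compound 2 to compound 4 (0.70 log units; beyond the scatter). For compound 4 the expected value is 15 nM, with an estimated range of 3 nM to 70 nM.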

Compound 4, half-maximal inhibitory concentration: 6 nM
For compound 4 the middle estimate is 2.5-fold (0.40 log units) above the measured one; the range from low to high includes it.
By their numbers in this assay, from the lowest: compounds 2 and 4 (each within the scatter of the next); then compound 3. At a limit, above all of these: compound 1.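

In this assay, swapping the group on a saturated chain carbon bound to an oxygen on an aromatic ring now has a measured size: a 2.0-fold higher number from compound 2 to compound 4 (0.30 log units; within the scatter). Isoquinolin-3-yl and 2-methyl-1,3-benzothiazol-6-yl, which brings a five-membered aromatic ring with 2 hetero atoms, therefore cannot be told apart here, so this place is not tied to isoquinolin-3-yl alone.

Going by these compounds, whether an amine or a carboxylic acid in place of the methyl on 2-methyl-1,3-benzothiazol-6-yl would read the same remains open. Nothing shown accounts for why these two groups read alike.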